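Changing the ring beside the methylsulfonyl group in acylguanidines

The compounds below may be only part of what the source reports. "The series", "measured", "known", "first", "only" and "open" are said of these compounds alone.

Measured compounds:
Compound 1 `Cc1cc(C2CCC2)c(S(C)(=O)=O)cc1C(=O)N=C(N)N` — 8.2 nM
Compound 2 `Cc1cc(Oc2cccc(Cl)c2)c(S(C)(=O)=O)cc1C(=O)N=C(N)N` — 21 nM

Within the data shown here, in a functional assay for inhibition of sodium/hydrogen exchanger (Oryctolagus cuniculus) (a lower number here means a stronger inhibitor, a higher number a weaker inhibitor), compound 2 gives 21 nM, the higher of the two numbers so far. Among the measured compounds shown here, compound 1 gives 8.2 nM, and the only known step, a 2.6-fold higher number from compound 1 to compound 2 (0.41 log units; beyond the scatter), shows that exchanging cyclobutyl for 3-chlorophenoxy weakened inhibition modestly. Compound 3 `Cc1cc(-n2cccn2)c(S(C)(=O)=O)cc1C(=O)N=C(N)N` is the next variation: 1H-pyrazol-1-yl in place of 3-chlorophenoxy on an aromatic carbon. For the measured compounds named here, no measured step covers this exact exchange, so the expectation leans on the one step available, which suggests that the group at this position changes the number only modestly. A small step is therefore expected, a 1.4-fold lower number from compound 2 to compound 3 (0.15 log units; within the scatter), without a clear direction beyond the scatter. Compound 3 is estimated at 15 nM, within a range from 5 nM to 45 nM in this assay.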

Compound 3, half-maximal inhibitory concentration: 25 nM
For compound 3 the middle estimate is 1.7-fold (0.22 log units) below the measured one, within the range that was stated.
By their numbers in this assay, from the lowest: compound 1; then compounds 2 and 3 (each within the scatter of the next).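

In this assay, the change of ring type makes little difference: a 1.2-fold higher number from compound 2 to compound 3 (0.08 log units; within the scatter) separates 1H-pyrazol-1-yl, a five-membered aromatic ring with 2 hetero atoms, from 3-chlorophenoxy, which carries a six-membered aromatic ring of carbon only. Cyclobutyl now stands apart from both aromatic groups, since a 3.0-fold higher number from compound 1 to compound 3 (0.48 log units; beyond the scatter) runs the same way as a 2.6-fold higher number from compound 1 to compound 2 (0.41 log units; beyond the scatter), so among these three compounds compound 1 is the strongest inhibitor. Nothing available explains why these groups compare as they do.

Three groups cannot show whether the lower number belongs to cyclobutyl alone or would also appear with a cyclopentyl or cyclopropyl ring. Going by these compounds, whether an amine or a longer chain on this aromatic carbon would match compound 1 also remains open.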